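A few compounds are considered here, and "the series" means these few. Any claim that something is new, unique, unknown or untested is made for them only; others in the source may bear on it.

Compound 2 `COc1ccc(-c2cc3ccccc3nc2/C=C/C(=O)c2ccc(OC)c(OC)c2)cc1` and compound 1 `COc1ccc(-c2cc3ccccc3nc2/C=C/C(=O)c2ccc(F)cc2)cc1` share one core and differ only in the aryl group on a carbonyl carbon. In a functional assay on MDA-MB-231 cells (Homo sapiens) for antiproliferative activity, read by XTT assay, with a stated time of 72 h (a lower number here means a stronger inhibitor, a higher number a weaker inhibitor), compound 1 gives 830 nM, and compound 2 gives 4790 nM. Going by the values given here, the one step measured so far, a 5.8-fold higher number from compound 1 to compound 2 (0.76 log units; beyond the scatter), shows that replacing 4-fluorophenyl with 3,4-dimethoxyphenyl on the carbonyl carbon weakens the inhibitor, and compound 2 therefore stands as the higher of the two numbers, with compound 1 as its nearest neighbour.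

Compound 3 `COc1ccc(-c2cc3ccccc3nc2/C=C/C(=O)c2cnc(N)nc2C)cc1` is not yet measured. It differs from compound 2 at the same carbonyl carbon: 2-amino-4-methylpyrimidin-5-yl in place of 3,4-dimethoxyphenyl on a carbonyl carbon. Among the compounds with values here, no measured step in this set bears directly on this exchange; the only step available, from compound 1 to compound 2, concerns a different pair of aryl groups at this carbon and gives no guidance on what an aminomethylpyrimidinyl group does here. The expectation for compound 3 in this assay is therefore centred close to compound 2, with a wide range, and the step of a 1.6-fold lower number from compound 2 to compound 3 (0.20 log units; within the scatter) is expected to lie within the scatter. Compound 3 is estimated at 3000 nM, between 700 nM and 12000 nM.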

Compound 3, half-maximal inhibitory concentration: > 10000 nM
Compound 3 ended at the assay's limit; the forecaster's own chance of this, stated with the estimate: 10%; middle value at least 3.3-fold (0.52 log units) from the limit.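

For compound 3, the reading of > 10000 nM in this assay is a limit of the assay and not a number: the limit of > 10000 nM in this assay, at which 1 of the 3 values shown sits. Even so, the steps can be read as bounds: 2-amino-4-methylpyrimidin-5-yl in place of 3,4-dimethoxyphenyl gives an at least 2.0-fold higher number from compound 2 to compound 3 (0.31 log units; beyond the scatter), and in place of 4-fluorophenyl it gives an at least 12-fold higher number from compound 1 to compound 3 (1.08 log units; beyond the scatter). The earlier pair held only aryl groups with a ring of carbon, whereas this result shows that a ring with two hetero atoms on the carbonyl carbon gives the highest number of the three, leaving compound 1 the strongest and compound 3 the weakest inhibitor shown.

Going by these compounds, how far the number of compound 3 lies past the limit stays open, and with it the true size of both steps. Also open, on these data alone, is whether the amine, the methyl group or the ring nitrogens carry the loss, which a pyridine ring, an unsubstituted pyrimidine or an aniline ring on the same carbonyl carbon could separate.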